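A few compounds are considered here, and "the series" means these few. Any claim that something is new, unique, unknown or untested is made for them only; others in the source may bear on it.

Measured so far in a functional assay on MDA-MB-231 cells (Homo sapiens) for antiproliferative activity, read by MTT assay, with a stated time of 24 h; on this read-out lower numbers stand for stronger inhibition and higher numbers for weaker inhibition:
- compound 1 `O=C(O)CC(NC(=O)c1ccc(C(F)(F)F)cc1)c1ccccc1F`: 59200 nM
- compound 2 `COc1ccc(C(=O)NC(CC(=O)O)c2ccc(Cl)cc2Cl)cc1`: > 100000 nM

Compound 2 sits at the limit of > 100000 nM in this assay, at which 1 of the 2 values shown sits, so its reading of > 100000 nM is a limit and not a number. Its true position is therefore open, and any step starting from it can be sized only roughly.

Compound 3 `O=C(O)CC(NC(=O)c1ccc(C(F)(F)F)cc1)c1ccc(Cl)cc1Cl` carries trifluoromethyl in place of methoxy on an aromatic carbon of a six-membered aromatic ring of carbon only, para to a large group (trifluoromethyl in place of methoxy on an aromatic carbon).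

For the measured compounds named here, no measured pair isolates this change. Going by the values given here, the only support comes from compound 1, which also carries trifluoromethyl and gives 59200 nM as a real number. A single compound makes no pattern, so the expectation stays weak.

A modest estimated step of an at least 2.0-fold lower number from compound 2 to compound 3 (0.30 log units; that floor lies within the scatter) is expected in this assay, in the direction of stronger inhibition.

For compound 3 the expected value is 50000 nM, with an estimated range from 18000 nM to 100000 nM and a real chance that only a limit is reported.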

Compound 3, half-maximal inhibitory concentration: 39100 nM
Beside the measured number, compound 3's estimate is 1.3-fold (0.11 log units) above it; the measured number falls inside the stated range.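

In this assay, trifluoromethyl in place of methoxy on an aromatic carbon, para to a large group, gives an at least 2.5-fold lower number from compound 2 to compound 3 (0.40 log units; beyond the scatter), so this place on the ring responds to the change by more than the usual scatter, which no earlier comparison could show. As far as these compounds go, compound 2 carries a limit and not a number, so that step is only a floor and its true size stays open: the limit of > 100000 nM in this assay, at which 1 of the 3 values shown sits. With trifluoromethyl held fixed, 2,4-dichlorophenyl in place of 2-fluorophenyl on the saturated chain carbon gives a 1.5-fold lower number from compound 1 to compound 3 (0.18 log units; within the scatter), so compound 1 and compound 3 cannot be told apart in this read-out, and this exchange shows no effect that stands clear of the scatter.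

The compounds shown leave open whether the gain belongs to trifluoromethyl itself, since a nitrile or a chlorine on the same aromatic carbon would be needed to tell, and whether the step from methoxy also holds with 2-fluorophenyl on the chain. Also open, from the compounds shown here alone, is how much of the reading depends on the carboxylic acid, which a methyl ester or a primary amide in its place would begin to address.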